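Amine swap from compound 3 to compound 4

The compounds below may be only part of what the source reports. "The series", "measured", "known", "first", "only" and "open" are said of these compounds alone.

Measured in a functional assay on HL60/MX2 cells (Homo sapiens) for antiproliferative activity, read by MTT assay, with a stated time of 48 h; on this read-out lower numbers stand for stronger inhibition and higher numbers for weaker inhibition:
- compound 1 `CCN(CC)CCn1c(N)c(-c2nc3ccccc3[nH]2)c2nc(C#N)c(C#N)nc21`: 7150 nM
- compound 2 `CCN(CC)CCn1c(N)c(-c2nc3ccccc3n2C)c2nc(C#N)c(C#N)nc21`: 3250 nM
- compound 3 `CN(C)CCn1c(N)c(-c2nc3cc(Cl)ccc3[nH]2)c2nc(C#N)c(C#N)nc21`: > 50000 nM, a limit and not a number

Compound 3 stands at the limit of > 50000 nM in this assay, at which 1 of the 3 values shown sits.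

Compound 4 `CCN(CC)CCn1c(N)c(-c2nc3cc(Cl)ccc3[nH]2)c2nc(C#N)c(C#N)nc21` has diethylamino in place of dimethylamino on a saturated chain carbon, two bonds along the chain from an aromatic nitrogen.

Within the data shown here, no measured step makes this amine change. The only one, a 2.2-fold lower number from compound 1 to compound 2 (0.34 log units; beyond the scatter), is modest and concerns methyl in place of hydrogen on an aromatic nitrogen, so it gives a sense of scale only. The closest guide is the shared diethylamino group: in this assay, compound 1 gives 7150 nM and compound 2 gives 3250 nM. Compound 3 also differs from both elsewhere, so the amine cannot be separated from those other differences, and a lower number is expected only tentatively.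

The expected change is an at least 5.0-fold lower number from compound 3 to compound 4 (0.69 log units; beyond the scatter).

Compound 4 is estimated at 10000 nM, with an expected range of 3000 nM to 40000 nM.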

Compound 4, half-maximal inhibitory concentration: 9290 nM
Estimate against measurement, compound 4: 1.1-fold (0.03 log units) above; measured number inside the range.
By their numbers in this assay, from the lowest: compound 2; then compounds 1 and 4 (each within the scatter of the next). At a limit, above all of these: compound 3.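

In this assay, the only amine step shown, on a saturated chain carbon two bonds along the chain from an aromatic nitrogen, gives an at least 5.3-fold lower number from compound 3 to compound 4 (0.73 log units; beyond the scatter), so the change from dimethylamino to diethylamino counts for much in the chloro-bearing pair. Compound 3 stands at a limit and not a number, so this step has a floor but no measured size: the limit of > 50000 nM in this assay, at which 1 of the 4 values shown sits. With diethylamino held constant, chloro in place of hydrogen gives a 1.3-fold higher number from compound 1 to compound 4 (0.11 log units; within the scatter), which shows no effect separable from the scatter, while 5-chloro-1H-benzimidazol-2-yl in place of 1-methyl-1H-benzimidazol-2-yl gives a 2.9-fold higher number from compound 2 to compound 4 (0.46 log units; beyond the scatter).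

As far as these compounds go, whether the amine step has the same size without the chloro remains open. Also open, from the compounds shown here alone, is how a cyclic amine such as pyrrolidine or morpholine, or a longer 3-(diethylamino)propyl chain, would read here.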